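The source may hold more compounds than are shown below. What is called first, only, known or untested is meant among the compounds shown, and "the series" means these compounds.

Of the compounds shown here, two of this set have been measured in a functional assay on DU-145 cells (Homo sapiens) for antiproliferative activity, read by MTT assay, with a stated time of 72 h; on this read-out lower numbers stand for stronger inhibition and higher numbers for weaker inhibition. Compound 1, `CCOc1ccccc1OCCSC(=S)N[C@H]1CCOC1=O`, is a dithiocarbamate bearing an ethoxy group on its aromatic ring; in this assay compound 1 gives 28300 nM. Compound 2, `CC(C)c1ccc(/C=C/C(=O)c2ccc(OCC(=O)N[C@H]3CCOC3=O)cc2)cc1`, is built on a different scaffold altogether, and in this assay compound 2 gives 13100 nM. Of the two numbers that of compound 1 is the higher, and the gap between them lies beyond the usual scatter, so compound 2 is the more potent of the pair on this read-out.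

Compound 3, `O=C1OCC[C@@H]1NC(=S)SCCOc1ccccc1[N+](=O)[O-]`, keeps the whole of compound 1 apart from one change: nitro in place of ethoxy on an aromatic carbon. Among the measured compounds shown here, no pair of measured compounds differs by such an exchange. The direction of the step is therefore open. With nothing in the measured compounds to point either way, the step from compound 1 to compound 3 is expected to stay within the scatter, that is a 1.1-fold lower number from compound 1 to compound 3 (0.05 log units; within the scatter). Compound 3 is therefore estimated at 25000 nM in this assay, with a plausible range from 8000 nM to 80000 nM.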

Compound 3, half-maximal inhibitory concentration: 33400 nM
Estimate against measurement, compound 3: 1.3-fold (0.13 log units) below; low and high end bracket the measured number.
By their numbers in this assay, from the lowest: compound 2; then compounds 1 and 3 (each within the scatter of the next).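

In this assay, the exchange of ethoxy for nitro on an aromatic carbon of the six-membered aromatic ring, ortho to a large group, gives a 1.2-fold higher number from compound 1 to compound 3 (0.07 log units; within the scatter), so the read-out does not separate compound 1 from compound 3. Among the compounds shown here, this is the first step in the set that can be read at this place, and it shows that the number stays within the scatter even though the two groups share only their count of heavy atoms and differ in their atoms, in the double bond outside aromatic rings that nitro brings and in their count of hydrogen-bond acceptors. No measurement on these compounds bears on the reason for this outcome.

The compounds shown leave open whether an amine or a carboxylic acid on the same aromatic carbon would also stay within the scatter of compound 1 or would move the number beyond it. They also leave open what a plain hydrogen or a longer chain such as butoxy would do there, so the tolerance seen rests on this single exchange.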